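Two nitroimidazole piperazines and a pyridyl analogue awaiting cytotoxicity

The source may hold more compounds than are shown below. What is called first, only, known or untested is meant among the compounds shown, and "the series" means these compounds.

The set rests on a shared core carrying a nitroimidazole linked through a hydroxypropyl chain to a piperazine. Compound 1 `COc1ccccc1N1CCN(C(=S)SCC(O)Cn2c([N+](=O)[O-])cnc2C)CC1` bears an aryl piperazine joined through a dithiocarbamate. In a toxicity assay on HeLa cells (Homo sapiens) for cytotoxicity, read by MTT assay, with a stated time of 24 h (on this read-out lower numbers stand for stronger inhibition and higher numbers for weaker inhibition), compound 1 returns only a limit of the assay, > 5000000 nM. Compound 2 `CCOC(=O)N1CCN(CC(O)Cn2c([N+](=O)[O-])cnc2C)CC1` carries an ethoxycarbonyl on the ring nitrogen, and in this assay compound 2 gives 3670000 nM. Among the numbers shown, compound 2 thus holds the only measured value, while the other entry is a limit (the limit of > 5000000 nM in this assay, at which 1 of the 2 values shown sits).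

Compound 3 `Cc1ncc([N+](=O)[O-])n1CC(O)CN1CCN(c2ccccn2)CC1` differs from compound 2 by pyridin-2-yl in place of ethoxycarbonyl on an amine nitrogen in a ring. Within the data shown here, no step between measured compounds is available to guide this change, so the expectation for compound 3 rests on the weak signal of compound 2 alone. The step from compound 2 to compound 3 in this assay is expected to stay within the usual scatter, a 1.0-fold lower number from compound 2 to compound 3 (0.02 log units; within the scatter), with a real chance that only a limit is reported. For compound 3 in this assay the estimate is 3500000 nM, ranging from 1000000 nM to 9000000 nM.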

Compound 3, half-maximal inhibitory concentration: 1830000 nM
Beside the measured number, compound 3's estimate is 1.9-fold (0.28 log units) above it; low and high end bracket the measured number.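

In this assay, among these compounds, placing pyridin-2-yl in place of ethoxycarbonyl on an amine nitrogen in a ring gives a 2.0-fold lower number from compound 2 to compound 3 (0.30 log units; within the scatter), the first step that can be read at this position. Exchanging a group with no ring for a six-membered aromatic ring with one hetero atom therefore leaves the two numbers within the scatter of each other, and no order can be drawn between the two compounds. The only limit among the values shown remains that of compound 1, which is a limit and not a number: the limit of > 5000000 nM in this assay, at which 1 of the 3 values shown sits.

As far as these compounds go, what remains open is whether any other group on this ring nitrogen would move the number beyond the scatter, since this single step cannot show a trend, and an acetyl, a benzyl or a free amine there could behave differently. From the compounds shown here alone, it is also open whether a plain phenyl ring, or a pyridine joined through a different ring carbon, would give a number like that of the pyridin-2-yl group.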